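Acyl variation on the shared core: working notes

The compounds below may be only part of what the source reports. "The series", "measured", "known", "first", "only" and "open" are said of these compounds alone.

Measured so far:
In a functional assay on WI-38 VA13 cells (Homo sapiens) for cytotoxicity (a lower number here means that less compound is needed, a higher number that more compound is needed for the effect), compound 1 `Cc1ccccc1C(=O)Nc1ccc2nc(NC(=O)C3CCCCC3)sc2c1` gives 0.085 ug/mL.
In this assay compound 2 `O=C(Nc1ccc2nc(NC(=O)C3CCCCC3)sc2c1)c1ccccc1Cl` gives 0.025 ug/mL.
In this assay compound 3 `O=C(Nc1ccc2nc(NC(=O)C3CCCCC3)sc2c1)c1ccc(Br)cc1` gives only a limit, > 4 ug/mL.

Compound 3 thus stands at the edge of what this assay reports: the limit of > 4 ug/mL in this assay, at which 1 of the 3 values shown sits. Among the numbers that are known, the two ortho-substituted aryl amides sit close together, with a 3.4-fold lower number from compound 1 to compound 2 (0.53 log units; beyond the scatter), while moving to the 4-bromophenyl amide costs heavily: an at least 47-fold higher number from compound 1 to compound 3 (1.67 log units; beyond the scatter) and an at least 160-fold higher number from compound 2 to compound 3 (2.20 log units; beyond the scatter).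

The next compound, compound 4 `CC(=O)Nc1ccc2nc(NC(=O)C3CCCCC3)sc2c1`, replaces the aryl amide altogether: methyl in place of 4-bromophenyl on a carbonyl carbon. For the measured compounds named here, no measured step exchanges an aryl for a small alkyl on this carbonyl, so nothing bears on it directly. The measured steps only show that the group on this carbonyl changes the read-out by large amounts in both directions, so a step beyond the scatter is expected for compound 4, more likely toward a lower number, because compound 3 sits at the limit of > 4 ug/mL in this assay, at which 1 of the 3 values shown sits.

The estimate for compound 4 in this assay is 1 ug/mL, with a range from 0.08 ug/mL to 4 ug/mL. The expected step is an at least 4.0-fold lower number from compound 3 to compound 4 (0.60 log units; beyond the scatter).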

Compound 4, half-maximal effective concentration: 2.7 ug/mL
Beside the measured number, compound 4's estimate is 2.7-fold (0.43 log units) below it, within the range that was stated.
By their numbers in this assay, from the lowest: compound 2; then compound 1; then compound 4. At a limit, above all of these: compound 3.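

With methyl on this carbonyl, the read-out in this assay lies far from both the 2-methylphenyl amide (a 32-fold higher number from compound 1 to compound 4 (1.50 log units; beyond the scatter)) and the 2-chlorophenyl amide (a 110-fold higher number from compound 2 to compound 4 (2.03 log units; beyond the scatter)). The low numbers of compound 1 and compound 2 therefore do not carry over to an acetyl group on the shared core, so within these compounds they go with those two substituted aryl groups, while compound 3 is the aryl amide that goes against any general aryl pattern. Compound 3 remains a limit, so the step (an at least 1.4-fold lower number from compound 3 to compound 4 (0.17 log units; that floor lies within the scatter)) gives only a floor and does not settle how the two compounds stand: the limit of > 4 ug/mL in this assay, at which 1 of the 4 values shown sits.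

Still open, as far as these compounds go, is whether the low numbers need the aryl ring alone or also its substituent, which an unsubstituted phenyl would address. From the compounds shown here alone, the effect of a longer alkyl chain or an amine on this carbonyl also remains unknown.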